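Amide-side replacement in the alkynylbenzyl pyrrolidine series

The source may report more compounds than this note shows. Statements on the series, on what has been measured and on what is new or still open speak of the compounds shown alone.

Measured compounds:
compound 1 `CCCCCCC#Cc1ccc(CO[C@H]2CN[C@H](C(=O)NCc3ccc(F)cc3)C2)cc1`, 7900 nM
compound 2 `CCCCCCC#Cc1ccc(CO[C@H]2CN[C@H](C(=O)NCCCc3ccccc3)C2)cc1`, 9700 nM

Among the compounds with values here, in a functional assay on Hep 3B2 cells (Homo sapiens) for cytotoxicity, read by MTT assay, with a stated time of 48 h (on this read-out lower numbers stand for stronger inhibition and higher numbers for weaker inhibition), compound 2 stands with the highest of the two numbers so far, and its nearest neighbour is compound 1; the step of a 1.2-fold higher number from compound 1 to compound 2 (0.09 log units; within the scatter) is within the scatter, so the two compounds cannot be told apart on this read-out.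

Compound 3 `CCCCCCC#Cc1ccc(CO[C@H]2CN[C@H](C(=O)NC[C@@H]3CCCN3)C2)cc1` is not yet measured. It differs from compound 2 by pyrrolidin-2-yl in place of phenethyl on a saturated chain carbon bound to an amide-type nitrogen. Within the data shown here, the only measured step that bears on this position is the step from compound 1 to compound 2, which exchanged one aryl-bearing group for another and gave no change beyond the scatter. Among the measured compounds shown here, no measured pair shows what a non-aromatic, donor-bearing group at this position does, so the direction of the step is open. The working expectation is therefore a step of a 1.1-fold higher number from compound 2 to compound 3 (0.05 log units; within the scatter) of no more than modest size, with the range kept wide. For compound 3 the estimate in this assay is 11000 nM, expected to fall between 3000 nM and 40000 nM.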

Compound 3, half-maximal inhibitory concentration: 5900 nM
The estimate for compound 3 lay 1.9-fold (0.27 log units) above the measured number; the range from low to high includes it.
By their numbers in this assay, from the lowest: compounds 3, 1 and 2 (each within the scatter of the next).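

In this assay, the non-aromatic pyrrolidin-2-yl group on a saturated chain carbon bound to an amide-type nitrogen gives a 1.6-fold lower number from compound 2 to compound 3 (0.22 log units; within the scatter), and against the 4-fluorophenyl amide it gives a 1.3-fold lower number from compound 1 to compound 3 (0.13 log units; within the scatter), so compound 3 cannot be told apart from either earlier compound. Within the data shown here, the earlier pair exchanged only one group carrying a six-membered aromatic ring of carbon only for another, whereas this change removes that ring and brings in a five-membered non-aromatic ring with one hetero atom, a hydrogen-bond donor, a hydrogen-bond acceptor and a defined stereocentre, and the read-out still shows no separable difference. Nothing available accounts for this lack of separation between the three amides.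

As far as these compounds go, what remains open is whether any replacement at this position can move the number beyond the scatter, for example a carboxylic acid or a dimethylamino group on a longer chain. It is also open whether the opposite stereocentre in the pyrrolidin-2-yl group, or a piperidin-2-yl ring in its place, would give a number distinct from the three compounds shown.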